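Notes on the series: compound 2 to compound 3

The compounds below may be only part of what the source reports. "The series", "measured", "known", "first", "only" and "open" are said of these compounds alone.

In a functional assay on MDA-MB-231 cells (Homo sapiens) for antiproliferative activity, read by MTT assay, with a stated time of 24 h (on this read-out higher numbers stand for weaker inhibition and lower numbers for stronger inhibition), compound 1 (`Cc1cccc(NNC(=O)c2ccc(NS(=O)(=O)c3cnc(O)nc3O)cc2)c1`) gives > 20000 nM as a limit and not a number. Compound 2 (`O=C(NNc1ccccc1F)c1ccccc1NS(=O)(=O)c1cnc(O)nc1O`) gives > 20000 nM, again only a limit. Compound 3 (`O=C(NNC(=O)c1ccccc1NS(=O)(=O)c1cnc(O)nc1O)c1ccccc1Cl`) differs from compound 2 by (2-chlorophenyl)carbonyl in place of 2-fluorophenyl on an amine nitrogen. Among the compounds with values here, no measured step informs this change, so no shift beyond the scatter is expected in this assay, and no direction is assigned. The expected step is a number no higher from compound 2 to compound 3 (the limit leaves the size open) in this estimate. For compound 3 the estimated value is 20000 nM, with an expected range from 8000 nM to 40000 nM.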

Compound 3, half-maximal inhibitory concentration: 8310 nM
For compound 3 the middle estimate is 2.4-fold (0.38 log units) above the measured one; the measured number falls inside the stated range.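

In this assay, within the data shown here, the change on this amine nitrogen gives an at least 2.4-fold lower number from compound 2 to compound 3 (0.38 log units; beyond the scatter) and yields the first value that is a number and not a limit. A group carrying a carbonyl on this nitrogen is thus compatible with a measurable value, which neither earlier compound showed. As far as these compounds go, the full size of the step stays open, since compound 2 has only a limit: the limit of > 20000 nM in this assay, at which 2 of the 3 values shown sit.

The carbonyl and the chlorine enter together, so their shares in the step cannot be separated. A (2-fluorophenyl)carbonyl group or an acetyl group on this nitrogen would bear on that question.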